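This account rests on a few compounds, and the source may have more. Where it says the series, first, only, none or still open, it means among the compounds named here.

In an assay on HEK293 cells for activation of Kir3.1/Kir3.2 (Homo sapiens), read by thallium flux (a higher number here means a larger maximal response, a lower number a smaller maximal response), three compounds have been measured:
Compound 1 `Cc1cc(NC(=O)Cn2nnc(-c3ccccc3)n2)n(C2CCCCC2)n1` gives 92%.
Compound 2 `CCC(C)n1nc(C)cc1NC(=O)Cn1nnc(-c2ccccc2)n1` reaches only a limit of the assay, > 69%.
Compound 3 `CC1CC1c1cc(NC(=O)Cn2nnc(-c3ccccc3)n2)n(C2CCCCC2)n1` gives 78%.

Compound 1 holds the highest of the two readable numbers; its nearest neighbour is compound 3, with a number 14 percentage points lower from compound 1 to compound 3 (beyond the scatter). The step that the limit leaves unreadable from compound 1 to compound 2 cannot be sized, because of the limit of > 69% in this assay, at which 1 of the 3 values shown sits.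

Compound 4 `Cc1cc(NC(=O)Cn2nnc(-c3ccnc(F)c3)n2)n(C2CCCCC2)n1` differs from compound 1 in one place: 2-fluoropyridin-4-yl in place of phenyl on an aromatic carbon. Neither measured step touches that part of the molecule, so there is no direct guide to its size. With no contrary evidence, the expected step is a number 6 percentage points lower from compound 1 to compound 4 (within the scatter), within the scatter. Compound 4 is therefore estimated at 86%, with a range from 66% to 102%.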

Compound 4, largest response reached (Emax), in percent of the reference or control that the assay uses: 95%
For compound 4 the middle estimate is 9 percentage points below the measured one; measured number inside the range.
By their numbers in this assay, from the lowest: compound 3; then compounds 1 and 4 (each within the scatter of the next).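

In this assay, 2-fluoropyridin-4-yl can take the place of phenyl on the aromatic carbon of the five-membered ring, with a number 3 percentage points higher from compound 1 to compound 4 (within the scatter) in maximal response. Within the data shown here, this is the first view of that position, and a ring nitrogen and a fluorine enter there while compounds 1 and 4 stay within the scatter of each other. Nothing measured here accounts for that outcome.

Going by these compounds, whether an amine or a carboxylic acid on that aromatic ring would be accepted as well stays open. So does whether 2-fluoropyridin-4-yl behaves the same with sec-butyl on the aromatic nitrogen.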